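Replacing the hydrazide arm with a tolyl group: cytotoxicity outlook

The compounds below may be only part of what the source reports. "The series", "measured", "known", "first", "only" and "open" are said of these compounds alone.

Compound 1, `N#CCC(=O)N/N=C1\C(=O)Nc2ccc(S(=O)(=O)N3CCOCC3)cc21`, gives 302000 nM in an ADME assay on WI-38 cells (Homo sapiens) for cytotoxicity, read by sulforhodamine B assay, with a stated time of 24 h; a higher number here means a weaker inhibitor, a lower number a stronger inhibitor.
Compound 2, `O=C1Nc2ccc(S(=O)(=O)N3CCOCC3)cc2/C1=N/NS(=O)(=O)c1ccccc1`, gives 302000 nM in this assay.
Compound 3, `O=C1Nc2ccc(S(=O)(=O)N3CCOCC3)cc2/C1=N/c1ccc(Cl)cc1`, gives 468000 nM in this assay.

Compound 1 stands level with compound 2, the two together at the lowest of the three numbers, and the gap to compound 3 is a 1.5-fold higher number from compound 1 to compound 3 (0.19 log units; within the scatter), so all three sit within the scatter of one another. Compound 4, `Cc1ccc(/N=C2\C(=O)Nc3ccc(S(=O)(=O)N4CCOCC4)cc32)cc1`, is not yet measured. It differs from compound 1 as follows: 4-methylphenyl in place of ((cyanomethyl)carbonyl)amino on a double-bonded nitrogen. The step that bears on this most directly is a 1.5-fold higher number from compound 1 to compound 3 (0.19 log units; within the scatter), where an aryl group replaced the same hydrazide arm on the double-bonded nitrogen, and a 1.5-fold higher number from compound 2 to compound 3 (0.19 log units; within the scatter) points the same way from the phenylsulfonyl analogue. Both were within the scatter. Compound 4 is therefore expected to show a step of about a 1.4-fold higher number from compound 1 to compound 4 (0.14 log units; within the scatter) in this assay, not beyond the scatter. The estimate for compound 4 is 420000 nM, with a range from 250000 nM to 700000 nM.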

Compound 4, half-maximal inhibitory concentration: 309000 nM
Compound 4: the middle estimate sits 1.4-fold (0.13 log units) above what was measured; low and high end bracket the measured number.
By their numbers in this assay, from the lowest: compounds 1, 2, 4 and 3 (each within the scatter of the next).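

In this assay, 4-methylphenyl on the double-bonded nitrogen brings no hydrogen-bond donor or acceptor, yet it gives a 1.0-fold higher number from compound 1 to compound 4 (0.01 log units; within the scatter) in place of ((cyanomethyl)carbonyl)amino and a 1.0-fold higher number from compound 2 to compound 4 (0.01 log units; within the scatter) in place of (phenylsulfonyl)amino, so a second aryl group at this position also stays within the scatter of both arms. The compounds now also allow a change within the aryl group itself, and methyl in place of chloro on an aromatic carbon gives a 1.5-fold lower number from compound 3 to compound 4 (0.18 log units; within the scatter), so this swap does not separate the two compounds either. No measurement at hand explains these numbers.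

The compounds shown leave open whether an amine or a carboxylic acid on that aromatic carbon, or a longer chain on the double-bonded nitrogen, would give a step beyond the scatter. They also leave open whether any change to the shared core would do so.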